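The source may hold more compounds than are shown below. What is called first, only, known or untested is meant among the compounds shown, and "the series" means these compounds.

Measured in a functional assay on HepG2 cells (Homo sapiens) for inhibition, read by MTT assay, with a stated time of 72 h; a higher number here means a weaker inhibitor, a lower number a stronger inhibitor:
- compound 1 `O=C1/C(=C\c2ccccc2)c2c(ncn2COCc2ccccc2)CCN1Cc1ccccc1` gives 13900 nM
- compound 2 `Cc1ccc(CN2CCc3ncn(COCc4ccccc4)c3/C(=C/c3ccccc3)C2=O)cc1` gives 44700 nM
- compound 3 `O=C1/C(=C\c2ccccc2)c2c(ncn2COCc2ccccc2)CCN1Cc1ccc(-c2ccccc2)cc1` gives 72500 nM

Compound 3 shares the high end of these numbers: a 1.6-fold higher number from compound 2 to compound 3 (0.21 log units; within the scatter) stays within the scatter, while a 5.2-fold higher number from compound 1 to compound 3 (0.72 log units; beyond the scatter) lies beyond it. Compound 4 `COc1ccc(CN2CCc3ncn(COCc4ccccc4)c3/C(=C/c3ccccc3)C2=O)cc1` differs from it in one place: methoxy in place of phenyl on an aromatic carbon that is, methoxy in place of phenyl on an aromatic carbon, para to a large group.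

Within the data shown here, no measured step involves methoxy. The closest guides are a 3.2-fold higher number from compound 1 to compound 2 (0.51 log units; beyond the scatter) and a 5.2-fold higher number from compound 1 to compound 3 (0.72 log units; beyond the scatter), both modest and both replacing hydrogen at this place. The second group in that pair of steps, methyl or phenyl, is not resolved by the data. The expected step in this assay is a 1.8-fold lower number from compound 3 to compound 4 (0.26 log units; within the scatter) toward a lower number, probably within the scatter. Compound 4 is estimated at 40000 nM (expected range 15000 nM to 95000 nM).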

Compound 4, half-maximal inhibitory concentration: 44400 nM
For compound 4 the middle estimate is 1.1-fold (0.05 log units) below the measured one; the measured number falls inside the stated range.
By their numbers in this assay, from the lowest: compound 1; then compounds 4, 2 and 3 (each within the scatter of the next).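

In this assay, methoxy at this place, on an aromatic carbon para to a large group, also separates from the hydrogen of the parent: a 3.2-fold higher number from compound 1 to compound 4 (0.50 log units; beyond the scatter) lies beyond the scatter. Neither a 1.0-fold lower number from compound 2 to compound 4 (0.00 log units; within the scatter) nor a 1.6-fold lower number from compound 3 to compound 4 (0.21 log units; within the scatter) leaves the scatter, so methoxy, methyl and phenyl cannot be told apart here. Nothing measured gives a reason for this.

From the compounds shown here alone, whether an amine or a carboxylic acid at this place would bring the number back toward that of compound 1 stays open. So does whether fluorine would differ from hydrogen here.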